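The source may hold more compounds than are shown below. What is called first, only, known or untested is meant among the compounds shown, and "the series" means these compounds.

In a functional assay (aorta) for inhibition, with Rattus norvegicus as the target (on this read-out higher numbers stand for weaker inhibition and lower numbers for stronger inhibition), compound 1 `Nc1nsc(-c2ccc(N3CCN(c4cccc(C(F)(F)F)c4)CC3)nn2)n1` gives 20 nM and compound 2 `CNc1nsc(-c2ccc(N3CCN(c4cccc(C(F)(F)F)c4)CC3)nn2)n1` gives 3 nM, the lower and therefore stronger of the two numbers. Within the data shown here, the only measured step is a 6.7-fold lower number from compound 1 to compound 2 (0.82 log units; beyond the scatter), with methyl in place of hydrogen on a nitrogen on an aromatic ring. Compound 3 `Cc1nsc(-c2ccc(N3CCN(c4cccc(C(F)(F)F)c4)CC3)nn2)n1` brings a different kind of change from compound 2: methyl in place of methylamino on an aromatic carbon. In short, this is methyl in place of methylamino on an aromatic carbon. Among the measured compounds shown here, the measured step bears on it only loosely, since that nitrogen is absent from compound 3, and no measured compound shows the effect of removing it. Compound 2 already holds the lowest number, so a modest move upward seems likeliest. The expected change is a 3.3-fold higher number from compound 2 to compound 3 (0.52 log units; beyond the scatter), and it remains quite uncertain. For compound 3 the estimated value is 10 nM, within an expected range of 2 nM to 50 nM.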

Compound 3, half-maximal inhibitory concentration: 0.3 nM
Compound 3: the middle estimate sits 33-fold (1.52 log units) above what was measured; the measured number lies below the stated range.
By their numbers in this assay, from the lowest: compound 3; then compound 2; then compound 1.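

On the aromatic carbon between two ring nitrogen atoms, the earlier pair showed only that a methyl on the amino nitrogen lowers the number, but in this assay removing that nitrogen altogether goes further, with a 10-fold lower number from compound 2 to compound 3 (1.00 log units; beyond the scatter). Measured against the amino group, the same carbon-bound methyl gives a 67-fold lower number from compound 1 to compound 3 (1.82 log units; beyond the scatter), so neither the amino nor the methylamino nitrogen is needed for a low number in these compounds. Nothing available here explains why replacing the nitrogen with methyl lowers the number so much.

On these data alone, what remains open is how an ethyl group, a methoxy group or a plain hydrogen on this carbon would compare with methyl. As far as these compounds go, it is also open whether this change would have a similar effect if the trifluoromethyl group were replaced by a chlorine atom.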